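This account rests on a few compounds, and the source may have more. Where it says the series, first, only, none or still open, it means among the compounds named here.

Working notes on the cytotoxicity series.

Three compounds have numbers in an ADME assay on H9c2 cells (Rattus norvegicus) for cytotoxicity, read by MTT assay, with a stated time of 48 h; on this read-out higher numbers stand for weaker inhibition and lower numbers for stronger inhibition. Compound 1 `O=C(NCCOC(=S)Nc1ccc([N+](=O)[O-])cc1Cl)c1cccnc1` is reported in this assay only as a limit, > 800000 nM, not as a number; (the limit of > 800000 nM in this assay, at which 1 of the 3 values shown sits). Compound 2 `Cc1ccc(NC(=S)OCCNC(=O)C(C)(C)Oc2ccc(Cl)cc2)cc1` gives 771000 nM in this assay. Compound 3 `Cc1cnc(C(=O)Oc2ccc(C(N)=S)cc2)c[n+]1[O-]` gives 780000 nM in this assay. Among the two numbers that are not limits, compound 2 and compound 3 sit within the scatter of each other, so no order between them can be read, and both lie close to the limit at which compound 1 sits. Among the compounds with values here, no pair of measured compounds differs in a single place, so no measured step is available.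

Compound 4 `CC(C)(Oc1ccc(Cl)cc1)C(=O)NCCOC(=S)Nc1ccc(F)cc1` has not yet been measured in this assay. It differs from compound 2 in one place: fluoro in place of methyl on an aromatic carbon. Within the data shown here, with no measured step to lean on, the expectation for this assay is a step from compound 2 to compound 4 of no size beyond the scatter, in either direction, since every number given so far sits near the top of the range. For compound 4 the estimate in this assay is therefore 770000 nM, expected to fall between 400000 nM and 1500000 nM, with the step of a 1.0-fold lower number from compound 2 to compound 4 (0.00 log units; within the scatter) expected to be within the scatter.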

Compound 4, half-maximal inhibitory concentration: > 800000 nM
Compound 4 ended at the assay's limit; the forecaster's own chance of this, stated with the estimate: 40%; at least 1.0-fold (0.01 log units) between middle value and limit.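

Within the data shown here, this is the first single-place step: in this assay, fluoro in place of methyl on an aromatic carbon, para to a large group, gives an at least 1.0-fold higher number from compound 2 to compound 4 (0.01 log units; that floor lies within the scatter). Compound 4 is reported only as a limit, > 800000 nM, not as a number. The step therefore shows that the 4-methylphenyl to 4-fluorophenyl change brings no fall in the number at this position and gives no measurable rise beyond the scatter, and the series stays at the top of the range: the limit of > 800000 nM in this assay, at which 2 of the 4 values shown sit.

How far compound 4 lies past its limit cannot be read. From the compounds shown here alone, it also remains open whether a different group at this position, such as an amine or a carboxylic acid, would give a clearly lower number in this assay.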